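Chloro scan on the amide aryl of a triazolopyridine series

The source may hold more compounds than are shown below. What is called first, only, known or untested is meant among the compounds shown, and "the series" means these compounds.

Measured in a functional assay on MCF7 cells (Homo sapiens) for antiproliferative activity, read by MTT assay, with a stated time of 72 h; a lower number here means a stronger inhibitor, a higher number a weaker inhibitor:
compound 1, `O=C(Nc1ccc(Cl)c(-c2nnc3c(Cl)cccn23)c1)c1ccc(C(F)(F)F)cc1Cl`, 81600 nM
compound 2, `O=C(Nc1ccc(Cl)c(-c2nnc3c(Cl)cccn23)c1)c1ccon1`, > 100000 nM
compound 3, `O=C(Nc1ccc(Cl)c(-c2nnc3c(Cl)cccn23)c1)c1ccccc1`, > 100000 nM

Compound 3 stands only at a limit of this assay, not at a number. Compound 2 likewise reaches only a limit. The step from compound 2 to compound 3, a step that the two limits leave unreadable from compound 2 to compound 3, is therefore unreadable, as the limit of > 100000 nM in this assay, at which 2 of the 3 values shown sit, notes. Within the data shown here, compound 1, which carries a chloro and a trifluoromethyl on the same ring as compound 3, is the one member of the set that yields a number at all, and that number sits close to the limit.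

Compound 4 is `O=C(Nc1ccc(Cl)c(-c2nnc3c(Cl)cccn23)c1)c1ccccc1Cl`. It differs from compound 3 in one place: chloro in place of hydrogen on an aromatic carbon. Among the measured compounds shown here, no measured step isolates this change, since compound 1 adds a second group at the same time. With compound 3 at a limit and compound 1 near it, no step beyond the scatter is expected in this assay from compound 3 to compound 4, a number no higher from compound 3 to compound 4 (the limit leaves the size open), and a limit reading remains the more likely outcome. Compound 4 is estimated at 100000 nM, within 40000 nM to 250000 nM.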

Compound 4, half-maximal inhibitory concentration: 92200 nM
For compound 4 the middle estimate is 1.1-fold (0.04 log units) above the measured one; the range from low to high includes it.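

In this assay, on these data alone, the chloro in place of hydrogen on an aromatic carbon, ortho to a large group, is enough to give compound 4 a readable number where compound 3 holds only a limit, with an at least 1.0-fold lower number from compound 3 to compound 4 (0.03 log units; that floor lies within the scatter); this is a floor only, so the true size of the step stays open. The comparison with the 1,2-oxazol-3-yl amide is of the same kind, with an at least 1.0-fold lower number from compound 2 to compound 4 (0.03 log units; that floor lies within the scatter). The trifluoromethyl of compound 1 adds nothing that can be told apart from the single chloro, with a 1.1-fold higher number from compound 1 to compound 4 (0.05 log units; within the scatter), so the number seen for compound 1 does not depend on that second group.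

As far as these compounds go, whether another group in the same place, such as a methoxy, an amine or a carboxylic acid, would move this series well clear of the limit stays open, as does any role of the amide aryl beyond this small set. The comparison between the phenyl and 1,2-oxazol-3-yl amides cannot be read, and no reading of either group's effect can be drawn from it: the limit of > 100000 nM in this assay, at which 2 of the 4 values shown sit.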